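Series notes: from compound 3 to compound 4

A few compounds are considered here, and "the series" means these few. Any claim that something is new, unique, unknown or untested is made for them only; others in the source may bear on it.

Measured in a physicochemical assay for solubility, read by HPLC, using the shake flask method, measured as kinetic solubility, with a stated time of 2 h, at pH 7.4; on this read-out higher numbers stand for higher solubility and lower numbers for lower solubility:
- compound 1 `Cc1cc(NCc2cnccn2)n2nc(C)c(-c3ccccc3)c2n1` gives 7100 nM
- compound 2 `Cc1cc(NCc2ncc[nH]2)n2nc(C)c(-c3ccccc3)c2n1` reads only as a limit, < 5000 nM
- compound 3 `Cc1cc(NCc2ccco2)n2nc(C)c(-c3ccccc3)c2n1` reads only as a limit, < 5000 nM

Compound 3 therefore stands at a limit of this assay, not at a number. This is the limit of < 5000 nM in this assay, at which 2 of the 3 values shown sit. Counted from compound 1, the steps are an at least 1.4-fold lower number from compound 1 to compound 2 (0.15 log units; that floor lies within the scatter) and an at least 1.4-fold lower number from compound 1 to compound 3 (0.15 log units; that floor lies within the scatter); between the two limits, a step that the two limits leave unreadable from compound 2 to compound 3. Compound 4 `Cc1cc(NCC2CCCCN2)n2nc(C)c(-c3ccccc3)c2n1` differs from compound 3 by piperidin-2-yl in place of furan-2-yl on a saturated chain carbon bound to a nitrogen on an aromatic ring. Going by the values given here, no measured step covers this change, so its size in this assay can only be guessed from the limit at which compound 3 sits. Compound 4 is expected to move upward, an at least 3.0-fold higher number from compound 3 to compound 4 (0.47 log units; beyond the scatter), beyond the scatter, though another limit reading remains possible. The estimate for compound 4 is 15000 nM, within 4000 nM to 60000 nM.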

Compound 4, solubility: 189000 nM
Estimate against measurement, compound 4: 13-fold (1.10 log units) below; the whole stated range lies below it.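

In this assay, the place on a saturated chain carbon bound to a nitrogen on an aromatic ring tolerates a large shift with piperidin-2-yl: an at least 37-fold higher number from compound 3 to compound 4 (1.57 log units; beyond the scatter), an at least 37-fold higher number from compound 2 to compound 4 (1.57 log units; beyond the scatter) and a 27-fold higher number from compound 1 to compound 4 (1.43 log units; beyond the scatter). Among the compounds shown, only compound 4 carries a six-membered non-aromatic ring here, so this single change accounts for the whole rise. The first two of these steps start from a limit, not a number: the limit of < 5000 nM in this assay, at which 2 of the 4 values shown sit.

Going by these compounds, whether the non-aromatic ring or its ring nitrogen carries the step stays open. Cyclohexyl or an open-chain primary amine at this place would separate the two.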